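The source may report more compounds than this note shows. Statements on the series, on what has been measured and on what is new or still open speak of the compounds shown alone.

Three compounds sharing a common core were examined in an ADME assay on HEL cells (Homo sapiens) for cytotoxicity; a lower number here means that less compound is tolerated, a higher number that more compound is tolerated. Compound 1, `O=C(COc1cccc2ccccc12)N/N=C/c1ccc(O)cc1`, gives 60.6 ug/mL. Compound 2, `O=C(COc1cccc2ccccc12)N/N=C/c1ccc(Br)cc1`, gives 100 ug/mL. These two differ in a single change, (hydroxy in place of bromo on an aromatic carbon), and that change produced a 1.7-fold lower number from compound 2 to compound 1 (0.22 log units; within the scatter). Compound 3, `C/C(=N\NC(=O)COc1cccc2ccccc12)c1ccc(Br)cc1`, gives 15.3 ug/mL, the lowest of the three numbers; the difference between its core and the core of compound 2 is not broken down here. Compound 4, `C/C(=N\NC(=O)COc1cccc2ccccc12)c1ccc(O)cc1`, has not yet been measured in this assay. It is reached from compound 3 by the same change as that from compound 2 to compound 1, namely (hydroxy in place of bromo on an aromatic carbon), at the same place on the ring. Because the earlier change gave a 1.7-fold lower number from compound 2 to compound 1 (0.22 log units; within the scatter), a step of similar size is expected for compound 4, that is a 1.3-fold lower number from compound 3 to compound 4 (0.11 log units; within the scatter). On that basis compound 4 is expected to give about 12 ug/mL, with a likely range from 6 ug/mL to 30 ug/mL.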

Compound 4, half-maximal cytotoxic concentration: 11.1 ug/mL
Estimate against measurement, compound 4: 1.1-fold (0.03 log units) above, within the range that was stated.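

In this assay, putting hydroxy in place of bromo on the second core gives a 1.4-fold lower number from compound 3 to compound 4 (0.14 log units; within the scatter). The change therefore reads alike on the two cores, and the earlier step carries over to this one in size: the same change on two cores in this assay, a 1.7-fold lower number (0.22 log units; within the scatter) from compound 2 to compound 1 and a 1.4-fold lower number (0.14 log units; within the scatter) from compound 3 to compound 4, 1.2-fold (0.08 log units) apart, within the scatter of two such steps
This does not show that the change itself moves the number on either core, since both steps lie within the scatter, and two pairs say nothing about how it would read on any further core or in any other assay.

The compounds shown leave open how an amine, a carboxylic acid or a methoxy group would read in place of bromo on an aromatic carbon, and whether a chloro or fluoro group would fall in line with the two groups seen here. They also leave open what a longer chain or a different group on the shared core would do to the number, on either the bromo or the hydroxy side.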